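Swapping nitro for dimethylamino on compound 2

The compounds below may be only part of what the source reports. "The series", "measured", "known", "first", "only" and "open" are said of these compounds alone.

- Compound 1 `COc1cc(OC)c(C(=O)/C=C/c2ccc(C(N)=O)cc2)c(OC)c1` gives 1790 nM
- Compound 2 `O=C(/C=C/c1ccccc1)c1ccccc1[N+](=O)[O-]` gives 1520 nM

In a functional assay for inhibition, with Homo sapiens as the target (on this read-out higher numbers stand for weaker inhibition and lower numbers for stronger inhibition), compound 2 gives 1520 nM while compound 1 gives 1790 nM and these two values lie within the usual scatter of each other. Compound 3 `CN(C)c1ccccc1C(=O)/C=C/c1ccccc1` differs from compound 2 in one place: dimethylamino in place of nitro on an aromatic carbon with dimethylamino in place of nitro on an aromatic carbon. Among the compounds with values here, no measured pair shows such a swap, so only a modest rise in the number, meaning somewhat weaker inhibition, is expected in this assay and a result within the scatter would be no surprise. The expected change is a 1.6-fold higher number from compound 2 to compound 3 (0.22 log units; within the scatter) as a rough estimate. For compound 3 the estimated value is 2500 nM with a likely range from 700 nM to 9000 nM on this read-out.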

Compound 3, half-maximal inhibitory concentration: 1770 nM
Estimate against measurement, compound 3: 1.4-fold (0.15 log units) above; the range from low to high includes it.
By their numbers in this assay, from the lowest: compounds 2, 3 and 1 (each within the scatter of the next).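

On this aromatic carbon, ortho to a large group, putting dimethylamino in place of nitro gives a 1.2-fold higher number from compound 2 to compound 3 (0.07 log units; within the scatter) in this assay. So two groups of 3 heavy atoms, built from different atoms, read alike at this position in this assay. Nothing measured here explains why they read alike. The compounds shown leave open how a primary amine or a carboxylic acid on this same carbon would read. They also leave open whether plain hydrogen there would read any differently.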